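This account rests on a few compounds, and the source may have more. Where it says the series, first, only, none or still open, it means among the compounds named here.

Compound 1 `Cc1ccc(S(=O)(=O)NCc2ccc(CNC(=O)c3ccc(F)cc3)cc2)cc1` gives 75% in a functional assay on the whole organism for inhibition, with Mus musculus as the target, with stated times of 30 min and 2 h, at a dose of 10 mg/kg by the intraperitoneal route (on this read-out higher numbers stand for more inhibition at the one dose given (going by the name of the read-out) and lower numbers for less inhibition), and compound 2 `Cc1ccc(S(=O)(=O)NCc2ccc(CNC(=O)c3ccccc3Cl)cc2)cc1` gives 26%, the lower of the two numbers measured here; the step of a number 49 percentage points lower from compound 1 to compound 2 (beyond the scatter) is large. Compound 3 `Cc1ccc(S(=O)(=O)NCc2ccc(CNC(=O)c3cccc(Cl)c3)cc2)cc1` differs from compound 2 by 3-chlorophenyl in place of 2-chlorophenyl on a carbonyl carbon. For the measured compounds named here, no measured step bears directly on this change: the one known step altered both the halogen and its place, so it offers little guidance. For compound 3 a moderate rise is estimated, a number 19 percentage points higher from compound 2 to compound 3 (beyond the scatter), with wide uncertainty. Compound 3 is therefore expected to reach about 45%, between 15% and 75%.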

Compound 3, a percentage reported as inhibition, in the whole organism at one dose (the size of the read-out at that dose, not a potency): 57%
Compound 3: the middle estimate sits 12 percentage points below what was measured, within the range that was stated.
By their numbers in this assay, from the lowest: compound 2; then compound 3; then compound 1.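

With the same atoms joined differently, 3-chlorophenyl in place of 2-chlorophenyl on a carbonyl carbon gives in this assay a number 31 percentage points higher from compound 2 to compound 3 (beyond the scatter) and so shows that the place of the chlorine alone can shift this read-out strongly. Against the fluorinated parent, the step is a number 18 percentage points lower from compound 1 to compound 3 (beyond the scatter) and remains modest, so a chlorine on this phenyl does not by itself bring the large fall seen with compound 2. No measurement here explains this dependence on place. On these data alone, it remains open how 4-chlorophenyl or 3-fluorophenyl would read, which would separate the halogen from its place. A methoxy group or a carboxylic acid on this phenyl is also untested among the compounds shown.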